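The source may report more compounds than this note shows. Statements on the series, on what has been measured and on what is new or still open speak of the compounds shown alone.

Of the compounds shown here, two built on one shared core have so far been measured in a functional assay on the whole organism with Rattus norvegicus as the target, read by paw edema, with a stated time of 3 h, at a dose of 100 mg/kg by the oral route; a higher number here means more inhibition at the dose given (going by the name of the read-out), a lower number less inhibition. Compound 1 `Cc1cccnc1-c1nc2ccccc2[nH]1` carries a methyl group on the six-membered ring, and in this assay compound 1 gives 17%. Compound 2 `CCc1cccc(-c2nc3ccccc3[nH]2)n1` carries an ethyl group at that position, and in this assay compound 2 gives 41%. Among the compounds with values here, of these two numbers, compound 2 stands highest; its nearest neighbour, compound 1, lies lower by a gap beyond the usual scatter, though with only two compounds this is a single observation and not a pattern.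

Compound 3 `COc1cccc(-c2nc3ccccc3[nH]2)n1` has not yet been measured. Relative to compound 2, it differs in one place: methoxy in place of ethyl on an aromatic carbon. The two groups match in heavy-atom count, but methoxy brings one hydrogen-bond acceptor that ethyl lacks. Within the data shown here, no measured pair isolates this exchange, so the writer can only frame an expectation. He expects the step from compound 2 to compound 3 in this assay to be a modest fall, a number 9 percentage points lower from compound 2 to compound 3 (within the scatter), one that may still sit within the scatter. For compound 3 he therefore estimates 32%, within a range from 12% to 52%.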

Compound 3, a percentage reported as inhibition, in the whole organism at one dose (the size of the read-out at that dose, not a potency): 47%
Compound 3: middle estimate off by 15 percentage points, on the low side; the measured number falls inside the stated range.
By their numbers in this assay, from the lowest: compound 1; then compounds 2 and 3 (each within the scatter of the next).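

The exchange of ethyl for methoxy on this aromatic carbon, next to the ring nitrogen, gives a number 6 percentage points higher from compound 2 to compound 3 (within the scatter) in this assay, so this read-out does not separate the two groups. The earlier compounds shown here could not show this, as neither of them carries an oxygen on the ring: here a carbon gives way to an oxygen, and one hydrogen-bond acceptor enters at an unchanged heavy-atom count, without a step beyond the scatter. The result therefore shows that, at this one dose, the position admits either group, and no measurement at hand bears on what lies behind this.

From the compounds shown here alone, whether the position would also admit an amine, a hydroxyl group or a longer chain such as propyl remains open, as does the effect of a bare hydrogen in its place, which would show whether either group contributes to the inhibition at all. Going by these compounds, since the read-out is taken at a single dose and a single time, it also remains open whether compound 2 and compound 3 would separate at other doses or at other times.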